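The source may hold more compounds than are shown below. What is called first, only, known or untested is meant among the compounds shown, and "the series" means these compounds.

Compound 1 has the structure `CCCNc1cc(Oc2c(OC)cc3cc(C#N)ccc3c2OC)nc(Nc2ccc(C#N)cc2)n1`. In an ADME assay on MT4 cells (Homo sapiens) for cytotoxicity, read by MTT assay, with a stated time of 5 days (a higher number here means that more compound is tolerated, a lower number that less compound is tolerated), compound 1 gives > 125000 nM, and this is a limit of the assay rather than a measured number. A close relative, compound 2, has the structure `COc1cc2cc(C#N)ccc2c(OC)c1Oc1cc(NCC2CCOCC2)nc(Nc2ccc(C#N)cc2)n1`. In this assay compound 2 gives > 125000 nM, again a limit of the assay. The step between these two, oxan-4-yl in place of ethyl on a saturated chain carbon bound to a nitrogen on an aromatic ring, reads a step that the two limits leave unreadable from compound 1 to compound 2. Going by the values given here, the only thing the measured pair shows is the limit of > 125000 nM in this assay, at which 2 of the 2 values shown sit.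

The compound still to be measured, compound 3, has the structure `COc1cc2cc(C#N)ccc2c(OC)c1Oc1cc(NC2CCOC2)nc(Nc2ccc(C#N)cc2)n1`. It differs from compound 1 by oxolan-3-yl in place of propyl on a nitrogen on an aromatic ring. Among the compounds with values here, the one step available, from compound 1 to compound 2, bears on it only loosely, since it carries a ring oxygen into the side chain on the same nitrogen, and its size could not be read. With both measured compounds sitting at the same limit, no step beyond the scatter is expected in this assay in either direction. Compound 3 is therefore expected to tolerate about 150000 nM, within 60000 nM to 400000 nM, a step that the limit leaves unreadable from compound 1 to compound 3.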

Compound 3, half-maximal cytotoxic concentration: > 125000 nM
Compound 3: no number, only a limit; the forecaster's own chance of this, stated with the estimate: 80%; the middle value does not contradict the limit.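

Compound 3 stops at a limit of the assay, just as compound 1 and compound 2 do, so no step among these three compounds can be read in this assay: the limit of > 125000 nM in this assay, at which 3 of the 3 values shown sit.

The compounds shown leave open how much of each is actually tolerated, and whether propyl, (oxan-4-yl)methyl and oxolan-3-yl on that nitrogen differ at all here.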